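The compounds below may be only part of what the source reports. "The series", "measured", "known", "first", "only" and "open" are said of these compounds alone.

Measured compounds in a functional assay on B16 cells (Mus musculus) for inhibition, tested at 10 uM; on this read-out lower numbers stand for less inhibition and higher numbers for more inhibition at the one concentration tested (going by the name of the read-out):
Compound 1 `Cc1ccc(/C=N/NC(N)=S)cc1` gives 64%.
Compound 2 `CC(C)(C)c1ccc(/C=N/NC(N)=S)cc1` gives > 100%, which is a limit of the assay and not a number.
Compound 3 `Cc1cccc(/C=N/NC(N)=S)c1` gives > 100%, again a limit of the assay rather than a number.

Compound 3 thus stands at the ceiling of what this assay reports, as shown by the limit of > 100% in this assay, at which 2 of the 3 values shown sit. Only compound 1 returns a number below that ceiling. Going by the values given here, the one step between measured compounds differing in a single place is a number at least 36 percentage points higher from compound 1 to compound 2 (beyond the scatter), a change in the alkyl group on the shared core.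

Compound 4 `NC(=S)N/N=C/c1cccc(Cl)c1` differs from compound 3 in one place: chloro in place of methyl on an aromatic carbon. Among the compounds with values here, no measured pair shows chloro in place of methyl, so no step bears directly on this change. Within the data shown here, the only step measured speaks to a different substitution and leaves the chloro question open.

Among the measured compounds shown here, since compound 3 already sits at the limit and the single measured change on this core also ends at the limit, compound 4 is expected to give a number near the ceiling in this assay. The expected step is a number at least 5 percentage points lower from compound 3 to compound 4 (that floor lies within the scatter), within the scatter. Compound 4 is estimated at 95%, with a range from 70% to 100%.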

Compound 4, a percentage reported as inhibition, at one concentration (the size of the read-out at that concentration, not a potency): > 100%
Compound 4: no number, only a limit (the forecaster's own chance of this, stated with the estimate: 50%); middle value at least 5 percentage points from the limit.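

In this assay no step can be read from compound 3 to compound 4, because both give a limit of the assay and not a number: the limit of > 100% in this assay, at which 3 of the 4 values shown sit.

The compounds shown leave open how compound 2, compound 3 and compound 4 compare with one another, and whether chloro in place of methyl on an aromatic carbon changes inhibition at all.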